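This account rests on a few compounds, and the source may have more. Where it says the series, first, only, none or still open, it means among the compounds named here.

Compound 1 `COc1ccc(/C=C2\S/C(=N\c3csc(-c4ccc(Cl)cc4)c3)NC2=O)cc1` and compound 2 `Cc1ccc(/C=C2\S/C(=N\c3csc(-c4ccc(Cl)cc4)c3)NC2=O)cc1` share one core and differ in a single place. In a functional assay on MCF7 cells (Homo sapiens) for cytotoxicity, read by MTT assay, with a stated time of 72 h (on this read-out higher numbers stand for weaker inhibition and lower numbers for stronger inhibition), compound 1 gives 1000 nM, and in this assay compound 2 gives 900 nM. The change between them, (methoxy in place of methyl on an aromatic carbon), made a step of a 1.1-fold higher number from compound 2 to compound 1 (0.05 log units; within the scatter).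

Compound 3 `COc1cccc(N2C(=O)CS/C2=N\c2csc(-c3ccc(C)cc3)c2)c1` is built on a different core, and the difference between the two cores is not broken down here. In this assay compound 3 returns only a limit, > 50000 nM, which is a limit of the assay and not a number; it is the value at which (the limit of > 50000 nM in this assay, at which 1 of the 3 values shown sits).

Compound 4 `COc1ccc(-c2cc(/N=C3\SCC(=O)N3c3cccc(OC)c3)cs2)cc1` has not yet been tested in this assay. It differs from compound 3 by methoxy in place of methyl on an aromatic carbon, the same change that separates compound 2 from compound 1. The two place descriptions agree word for word, so the change is taken as the same one.

That earlier step stayed within the scatter of repeated measurements, and compound 3 sits at the limit of this assay. On that footing the step from compound 3 to compound 4 is expected to be small, a step that the limit leaves unreadable from compound 3 to compound 4, and compound 4 is expected to come out near the same limit. The estimate for compound 4 in this assay is 60000 nM, with a range expected from 20000 nM to 200000 nM, and it is likely that the assay again reports only a limit rather than a number.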

Compound 4, half-maximal inhibitory concentration: 1900 nM
Compound 4: the middle estimate sits 32-fold (1.50 log units) above what was measured, outside the stated range (below it).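

In this assay, methoxy in place of methyl, read on the group as 4-methylphenyl to 4-methoxyphenyl, gave an at least 26-fold lower number from compound 3 to compound 4 (1.42 log units; beyond the scatter), and this step does not match the earlier one on the other core: the same change on two cores in this assay, a 1.1-fold higher number (0.05 log units; within the scatter) from compound 2 to compound 1 and an at least 26-fold lower number (1.42 log units; beyond the scatter) from compound 3 to compound 4, at least 29-fold (1.46 log units) apart, beyond the scatter of two such steps

Compound 3 has only a limit of the assay, > 50000 nM, so the step has a floor and no known size: the limit of > 50000 nM in this assay, at which 1 of the 4 values shown sits.

The two pairs show that in this series the size of this change did not carry over from one core to the other, but they do not show which feature of the cores sets the difference, and two pairs give no general rule for where the change will matter.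

The compounds shown leave open whether the large step is particular to methoxy or would also appear with other groups at the same place on the core of compound 3, such as a hydroxyl, an amine, an ethoxy or a carboxylic acid. They also leave open whether the same change would give a step of similar size on further cores, or whether the two steps seen here mark the extremes of its range.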